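The source may hold more compounds than are shown below. What is called first, only, known or untested is meant among the compounds shown, and "the series" means these compounds.

The compounds measured in a functional assay on HepG2 cells (Homo sapiens) for antiproliferative activity, read by MTT assay, with a stated time of 48 h (a lower number here means a stronger inhibitor, a higher number a weaker inhibitor), are these: compound 1 `COc1ccc(/C=C/c2cc(OC)cc(OC)c2/C=C/C(=O)c2cccc(OC)c2)cc1` with 11.6 ug/mL; compound 2 `CCCC(C)Oc1ccc(C(=O)/C=C/c2c(/C=C/c3ccc(OC)cc3)cc(OC)cc2OC)cc1` with 11.1 ug/mL; compound 3 `COc1ccc(/C=C/c2cc(OC)cc(OC)c2/C=C/C(=O)c2ccc(C)c(C)c2)cc1` with 0.2 ug/mL.

Compound 2 holds the second highest of the three numbers. Compound 1 sits nearest, and the pair differs only within the scatter, as a 1.0-fold lower number from compound 1 to compound 2 (0.02 log units; within the scatter) shows. Compound 3 stands furthest away, with a 56-fold lower number from compound 2 to compound 3 (1.74 log units; beyond the scatter).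

Compound 4 `CCN(CC)c1ccc(C(=O)/C=C/c2c(/C=C/c3ccc(OC)cc3)cc(OC)cc2OC)cc1` is not yet measured. It differs from compound 2 as follows: diethylamino in place of 1-methylbutoxy on an aromatic carbon, the change sitting para to a large group on the same six-membered aromatic ring of carbon only. The two measured steps at this carbonyl-borne ring bear on it: the swap of one oxygen-linked group for another left the number unchanged within the scatter, while the swap to 3,4-dimethylphenyl gave a large drop. Among the compounds with values here, no measured step carries a diethylamino group, so the size of the step in this assay for compound 4 is uncertain; a shift of moderate size in either direction, or none beyond the scatter, is expected, a 1.4-fold lower number from compound 2 to compound 4 (0.14 log units; within the scatter). Compound 4 is therefore estimated at 8 ug/mL, within the range 2 ug/mL to 30 ug/mL.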

Compound 4, half-maximal inhibitory concentration: 6.3 ug/mL
Beside the measured number, compound 4's estimate is 1.3-fold (0.10 log units) above it, within the range that was stated.
By their numbers in this assay, from the lowest: compound 3; then compounds 4, 2 and 1 (each within the scatter of the next).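

With diethylamino in place of 1-methylbutoxy, a nitrogen-linked group now stands at this aromatic carbon, and the step is only a 1.8-fold lower number from compound 2 to compound 4 (0.25 log units; within the scatter). The step from the 3-methoxyphenyl group is also small, a 1.8-fold lower number from compound 1 to compound 4 (0.27 log units; within the scatter), whereas the gap to the 3,4-dimethylphenyl group stays large, a 32-fold higher number from compound 3 to compound 4 (1.50 log units; beyond the scatter), so the nitrogen-linked group falls with the oxygen-linked ones. Nothing available explains this result.

Going by these compounds, whether a smaller amine such as dimethylamino or a cyclic amine such as morpholine would behave likewise remains open. So does whether a single methyl group on this ring would be enough to produce the large drop.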